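The source may report more compounds than this note shows. Statements on the series, on what has been measured and on what is new or still open speak of the compounds shown alone.

Measured so far in a functional assay on A549 cells (Homo sapiens) for inhibition, with a stated time of 72 h; a higher number here means a weaker inhibitor, a lower number a stronger inhibitor:
- compound 1 `O=C(Nc1ccc(Cl)cc1)Nc1nc(Sc2c[nH]c3ccccc23)cc(N2CCCC2)n1` gives 6410 nM
- compound 2 `Cc1cc(Cl)ccc1NC(=O)Nc1nc(Sc2c[nH]c3ccccc23)cc(N2CCCC2)n1` gives 8930 nM
- compound 3 `COc1ccc(NC(=O)Nc2nc(Sc3c[nH]c4ccccc34)cc(N3CCN(c4ccccn4)CC3)n2)cc1` gives > 50000 nM

Compound 3 stands at the limit of this assay, (the limit of > 50000 nM in this assay, at which 1 of the 3 values shown sits), so for compound 3 only a limit and no number is known. The change from compound 3 to compound 4 `COc1ccc(NC(=O)Nc2nc(Sc3c[nH]c4ccccc34)cc(N3CCCC3)n2)cc1` is pyrrolidin-1-yl in place of 4-(pyridin-2-yl)piperazin-1-yl on an aromatic carbon. Among the compounds with values here, the one measured step, a 1.4-fold higher number from compound 1 to compound 2 (0.14 log units; within the scatter), concerns a different site and does not bear on this change. What does bear on it is that compound 1 and compound 2, both carrying the pyrrolidin-1-yl that enters, give numbers in this assay, whereas compound 3, carrying the 4-(pyridin-2-yl)piperazin-1-yl that leaves, gives only a limit. Compound 4 also keeps the (4-methoxyphenyl)carbamoyl)amino group of compound 3, for which no separate comparison exists, so the expectation is loose. Compound 4 is expected to give a measurable number, estimated at 15000 nM, with a range from 5000 nM to 50000 nM. The expected step is an at least 3.3-fold lower number from compound 3 to compound 4 (0.52 log units; beyond the scatter), toward a stronger inhibitor.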

Compound 4, half-maximal inhibitory concentration: 11800 nM
Compound 4: the middle estimate sits 1.3-fold (0.10 log units) above what was measured; the measured number falls inside the stated range.
By their numbers in this assay, from the lowest: compounds 1, 2 and 4 (each within the scatter of the next). At a limit, above all of these: compound 3.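

In this assay, with the ((4-methoxyphenyl)carbamoyl)amino group kept, pyrrolidin-1-yl in place of 4-(pyridin-2-yl)piperazin-1-yl gives an at least 4.2-fold lower number from compound 3 to compound 4 (0.62 log units; beyond the scatter). Compound 3 remains a limit, so this step is only a lower bound: the limit of > 50000 nM in this assay, at which 1 of the 4 values shown sits. With pyrrolidin-1-yl held, the change on the other arm stays within the scatter: 4-methoxyphenyl in place of 4-chloro-2-methylphenyl gives a 1.3-fold higher number from compound 2 to compound 4 (0.12 log units; within the scatter), and methoxy in place of chloro gives a 1.8-fold higher number from compound 1 to compound 4 (0.27 log units; within the scatter).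

Open, from the compounds shown here alone, is which part of the 4-(pyridin-2-yl)piperazin-1-yl group goes with the limit; a plain piperazine or a morpholine at this position would separate the six-membered ring from the pyridine. Also open, going by these compounds, is whether another small amine here, such as dimethylamino or piperidine, would shift the number beyond the scatter from compound 4.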